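Moving the fluorine on the pyridine: compound 3 expected

This account rests on a few compounds, and the source may have more. Where it says the series, first, only, none or still open, it means among the compounds named here.

Measured so far:
- compound 1 `Cc1cn2c(-c3cn[nH]c3)cnc2c(Nc2cc(Cc3ncccc3C)ns2)n1`: 644 ng.h/mL
- compound 2 `Cc1cn2c(-c3cn[nH]c3)cnc2c(Nc2cc(Cc3ccc(F)cn3)ns2)n1`: 2240 ng.h/mL

Compound 1 and compound 2 were measured in an ADME assay on the whole organism for pharmacokinetics, with Rattus norvegicus as the target, with a stated time of 6 h, at a dose of 10 mg/kg by the oral route; a lower number here means less compound in the circulation, a higher number more compound in the circulation at the dose given. Within the data shown here, compound 2 stands highest of the two numbers; its nearest neighbour is compound 1, and the single change between them gave a 3.5-fold higher number from compound 1 to compound 2 (0.54 log units; beyond the scatter). That step swaps the whole pyridine substituent, so it speaks to how much this part of the molecule can move the read-out, but not to where a fluorine sits on the ring.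

Compound 3 `Cc1cn2c(-c3cn[nH]c3)cnc2c(Nc2cc(Cc3cccc(F)n3)ns2)n1` differs from compound 2 by 6-fluoropyridin-2-yl in place of 5-fluoropyridin-2-yl on a saturated chain carbon bound to an aromatic carbon. Among the measured compounds shown here, no measured step shows a fluorine shifted from one ring position to another, so the step from compound 1 to compound 2 is the only bearing, and it bears only loosely. A small shift of this kind is expected to stay near compound 2, with some room to slip back toward compound 1; the estimated step is a 1.5-fold lower number from compound 2 to compound 3 (0.17 log units; within the scatter). Compound 3 is therefore expected at about 1500 ng.h/mL in this assay, within a range of 500 ng.h/mL to 4500 ng.h/mL.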

Compound 3, area under the concentration-time curve: 2970 ng.h/mL
Compound 3: the middle estimate sits 2.0-fold (0.30 log units) below what was measured; low and high end bracket the measured number.
By their numbers in this assay, from the lowest: compound 1; then compounds 2 and 3 (each within the scatter of the next).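

In this assay, moving the fluorine on the pyridine ring does not separate the two compounds: replacing 5-fluoropyridin-2-yl with 6-fluoropyridin-2-yl gives a 1.3-fold higher number from compound 2 to compound 3 (0.12 log units; within the scatter), so this read-out cannot tell the two placements apart. Replacing 3-methylpyridin-2-yl with 6-fluoropyridin-2-yl gives a 4.6-fold higher number from compound 1 to compound 3 (0.66 log units; beyond the scatter), and alongside a 3.5-fold higher number from compound 1 to compound 2 (0.54 log units; beyond the scatter) this shows that the separation from compound 1 holds for two fluorine placements, not just one. No measurement available here explains these numbers.

The compounds shown cannot say whether the separation from compound 1 depends on the fluorine being present or on the methyl being absent, as that would take a plain pyridin-2-yl group with neither substituent for comparison. On these data alone, it also remains open whether a chlorine or a methoxy group in the fluorine's place would keep the number near those of compound 2 and compound 3, or whether an amine there would bring it back toward compound 1.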